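A few compounds are considered here, and "the series" means these few. Any claim that something is new, unique, unknown or untested is made for them only; others in the source may bear on it.

In a functional assay on MGC-803 cells (Homo sapiens) for inhibition, read by CCK-8 assay, with a stated time of 48 h (a higher number here means a weaker inhibitor, a lower number a stronger inhibitor), compound 2 `COc1cc(N(Cc2ccc(Cl)cc2)C(=O)CSC(=S)N2CCN(C(=O)OC(C)(C)C)CC2)cc(OC)c1OC` gives 12900 nM and compound 1 `COc1ccc(CN(C(=O)CN2CCN(C(=O)OC(C)(C)C)CC2)c2cc(OC)c(OC)c(OC)c2)cc1` gives 9500 nM, two values within the scatter of each other. Compound 3 `COc1ccc(CN(C(=O)CSC(=S)N2CCN(C(=O)OC(C)(C)C)CC2)c2cc(OC)c(OC)c(OC)c2)cc1F` carries 3-fluoro-4-methoxyphenyl in place of the 4-chlorophenyl of compound 2, on a saturated chain carbon bound to an amide-type nitrogen (3-fluoro-4-methoxyphenyl in place of 4-chlorophenyl on a saturated chain carbon bound to an amide-type nitrogen). Among the measured compounds shown here, no measured pair isolates this change. In this assay the expected step is therefore small, with no shift beyond the scatter: a 1.4-fold lower number from compound 2 to compound 3 (0.16 log units; within the scatter). For compound 3 the estimated value is 9000 nM, with an expected range of 3000 nM to 22000 nM.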

Compound 3, half-maximal inhibitory concentration: 4870 nM
Estimate against measurement, compound 3: 1.8-fold (0.27 log units) above; the measured number falls inside the stated range.
By their numbers in this assay, from the lowest: compounds 3, 1 and 2 (each within the scatter of the next, the first and the last beyond it).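

In this assay, the aryl group on a saturated chain carbon bound to an amide-type nitrogen proves able to move the number: 3-fluoro-4-methoxyphenyl in place of 4-chlorophenyl gives a 2.6-fold lower number from compound 2 to compound 3 (0.42 log units; beyond the scatter) as a modest step, the first single-place change readable in the series. The change swaps the chlorine for both a fluorine and a methoxy group, so the step cannot be assigned to either one. No evidence at hand bears on this step. The compounds shown leave open how a 3-fluorophenyl or a 4-aminophenyl group would read at this place.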